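Isopropylcarbonyl in place of the dimethylcarbamoylethyl chain

The source may report more compounds than this note shows. Statements on the series, on what has been measured and on what is new or still open speak of the compounds shown alone.

Among the compounds with values here, compound 3 `Cc1c(F)c(Oc2cccc(CCC(=O)N(C)C)c2)nc(Oc2cccc(C(=N)N)c2)c1F` is the only member of the series with a numerical reading in an assay on isolated protein for inhibition of serine protease 1 (Bos taurus); a lower number here means a stronger inhibitor, a higher number a weaker inhibitor: compound 3 gives 4900 nM. Compound 1 `Cc1c(F)c(Oc2cccc(C(=N)N)c2)nc(Oc2cccc(C(=O)O)c2)c1F` returns only the assay limit, > 5000 nM. Compound 2 `Cc1c(F)c(Oc2cccc(CC(N)=O)c2)nc(Oc2cccc(C(=N)N)c2)c1F` likewise returns only the limit, > 5000 nM. Both sit at the limit of > 5000 nM in this assay, at which 2 of the 3 values shown sit. Compound 4 `Cc1c(F)c(Oc2cccc(C(=N)N)c2)nc(Oc2cccc(C(=O)C(C)C)c2)c1F` carries the change (isopropylcarbonyl in place of 2-(dimethylcarbamoyl)ethyl on an aromatic carbon). The steps that touch the same aromatic carbon, an at least 1.0-fold lower number from compound 1 to compound 3 (0.00 log units; that floor lies within the scatter) and an at least 1.0-fold lower number from compound 2 to compound 3 (0.00 log units; that floor lies within the scatter), are readable only as floors that lie within the scatter, so no exchange at that position has yet moved the number noticeably. For compound 4 the expected step of a 1.1-fold higher number from compound 3 to compound 4 (0.05 log units; within the scatter) is therefore none beyond the scatter, with a fair chance that only the limit is returned again. Compound 4 is estimated at 5500 nM, within 2500 nM to 12000 nM.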

Compound 4, inhibition constant: 3800 nM
Compound 4: the middle estimate sits 1.4-fold (0.16 log units) above what was measured, within the range that was stated.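

In this assay a second numerical reading now stands at this aromatic carbon: the exchange of 2-(dimethylcarbamoyl)ethyl for isopropylcarbonyl gives a 1.3-fold lower number from compound 3 to compound 4 (0.11 log units; within the scatter), so a numerical reading here does not depend on the dimethylcarbamoyl chain. Against the other two groups only floors can be read, an at least 1.3-fold lower number from compound 2 to compound 4 (0.11 log units; that floor lies within the scatter) and an at least 1.3-fold lower number from compound 1 to compound 4 (0.11 log units; that floor lies within the scatter), and neither shows a change beyond the scatter. Those two steps stay floors because compound 1 and compound 2 each return a limit: the limit of > 5000 nM in this assay, at which 2 of the 4 values shown sit.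

Going by these compounds, whether an amine or a longer chain ending in a carboxylic acid at this aromatic carbon would move the number beyond the scatter stays open.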